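Ortho-methyl on the biaryl of compound 2

The compounds below may be only part of what the source reports. "The series", "measured", "known", "first", "only" and "open" are said of these compounds alone.

Going by the values given here, compound 2 `CN(Cc1ccc2nccn2c1)c1nnc(-c2ccc(-c3ccccc3)cc2)o1` stands highest of the two numbers so far in a physicochemical assay for lipophilicity, at pH 7.4 (a lower number here means a more polar compound, a higher number a more lipophilic compound), where compound 2 gives 3.9. Among the compounds with values here, the nearest neighbour is compound 1 `CN(Cc1ccc2nccn2c1)c1nnc(-c2ccc(C3CC3)cc2)o1`, which in this assay gives 3.5; the step of a number 0.40 log units higher from compound 1 to compound 2 (beyond the scatter) is the only measured step and records a change of one aromatic substituent for another. Compound 3 `Cc1ccccc1-c1ccc(-c2nnc(N(C)Cc3ccc4nccn4c3)o2)cc1` is the next member, differing from compound 2 by methyl in place of hydrogen on an aromatic carbon. Within the data shown here, no measured step covers a methyl entering an aromatic carbon, so the step from compound 1 to compound 2 bears on it only as a general indication that adding carbon on this distal aryl raises the number in this assay . The change from compound 2 to compound 3 is smaller in size than that step: one carbon enters, with no hydrogen-bond donor or acceptor and no charge. A modest rise is therefore expected, a number 0.30 log units higher from compound 2 to compound 3 (within the scatter), at the edge of the scatter rather than clearly beyond it. For compound 3 the expected value in this assay is 4.2, with a range from 3.8 to 4.6.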

Compound 3, distribution coefficient: 4.7
Estimate against measurement, compound 3: 0.50 log units below; measured number above the stated range.
By their numbers in this assay, from the lowest: compound 1; then compound 2; then compound 3.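

Methyl in place of hydrogen on an aromatic carbon, ortho to a large group, is the first change at this position, and in this assay it gives a step (a number 0.80 log units higher from compound 2 to compound 3 (beyond the scatter)) larger than the one printed for phenyl in place of cyclopropyl (a number 0.40 log units higher from compound 1 to compound 2 (beyond the scatter)). A single added carbon, with no hydrogen-bond donor, no hydrogen-bond acceptor and no net charge, therefore moves the number here further than the exchange of one whole aromatic substituent for another did in the earlier pair. With 2-methylphenyl in place of cyclopropyl the series now holds its first large step (a number 1.20 log units higher from compound 1 to compound 3 (beyond the scatter)), and compound 3 stands highest of the three; the data shown offer nothing that accounts for the size of the methyl step.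

The compounds shown leave open whether this rise in this assay belongs to methyl at this carbon alone, or would also follow from methyl on another carbon of the same ring. They also leave open what an ethyl, a methoxy, an amine or a carboxylic acid on this same carbon would do to the number.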